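Replacing the Aminoalkyl Chain with Trifluoromethyl

This account rests on a few compounds, and the source may have more. Where it says the series, first, only, none or still open, it means among the compounds named here.

Compound 1: `N#Cc1ncncc1-c1nc2cc(F)c(F)cc2n1C1CC1` — 13 nM
Compound 2: `Fc1cc2nc(-c3cncnc3NCCC(F)(F)F)n(C3CC3)c2cc1F` — 3 nM

In an assay on cells for inhibition of cytochrome P450 11B2, mitochondrial (Homo sapiens), read by HPLC, with a stated time of 90 min (on this read-out lower numbers stand for stronger inhibition and higher numbers for weaker inhibition), compound 2 stands lowest of the two numbers. For the measured compounds named here, the only measured step is a 4.3-fold lower number from compound 1 to compound 2 (0.64 log units; beyond the scatter). Compound 3 is `Fc1cc2nc(-c3cncnc3C(F)(F)F)n(C3CC3)c2cc1F`; the change is trifluoromethyl in place of (3,3,3-trifluoropropyl)amino on an aromatic carbon. Going by the values given here, no measured step covers trifluoromethyl at this position, so that step bears only loosely, showing that this position responds to substitution. A modest rise in number is expected for compound 3, 10 nM with a range of 3 nM to 40 nM. The expected step is a 3.3-fold higher number from compound 2 to compound 3 (0.52 log units; beyond the scatter).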

Compound 3, half-maximal inhibitory concentration: 25 nM
For compound 3 the middle estimate is 2.5-fold (0.40 log units) below the measured one; measured number inside the range.
By their numbers in this assay, from the lowest: compound 2; then compounds 1 and 3 (each within the scatter of the next).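

In this assay this position proves sensitive to the change, with an 8.3-fold higher number from compound 2 to compound 3 (0.92 log units; beyond the scatter): trifluoromethyl set directly on the aromatic carbon does not match the (3,3,3-trifluoropropyl)amino chain. Trifluoromethyl and cyano are not told apart here, with a 1.9-fold higher number from compound 1 to compound 3 (0.28 log units; within the scatter), so compound 2 alone stands out among the three. Nothing available explains these results.

The compounds shown leave open whether the lower number of compound 2 depends on the chain's nitrogen or on its length. An unsubstituted amine or a longer alkylamino chain on this carbon would bear on that question.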